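This account rests on a few compounds, and the source may have more. Where it says the series, first, only, none or still open, it means among the compounds named here.

Working notes on the series in an assay on isolated protein for inhibition of serine/threonine-protein kinase Chk2 (Homo sapiens), read by mobility shift assay, tested at 30 uM; a higher number here means more inhibition at the concentration tested (going by the name of the read-out), a lower number less inhibition. Compound 1 `Nc1n[nH]c2cc(-c3cccnc3)[nH]c(=O)c12` gives 27%, compound 2 `COc1ccc(-c2cc3c(c(N)nn3C)c(=O)[nH]2)cc1` gives 16%, and compound 3 `CC(C)(C)c1cc2nn(-c3ccccc3)c(N)c2c(=O)[nH]1` gives 5%, the lowest of the three numbers; its gap to compound 2 and its gap to compound 1 both lie beyond the scatter. Compound 4 `COc1ccccc1-c1cc2nn(-c3ccccc3)c(N)c2c(=O)[nH]1` is not yet measured. The change from compound 3: 2-methoxyphenyl in place of tert-butyl on an aromatic carbon Compounds 1 and 2 each carry an aromatic ring on the shared core and both sit higher than compound 3, which suggests a rise for compound 4, though no measured step sizes such a change. In this assay the expected step is a number 10 percentage points higher from compound 3 to compound 4 (within the scatter), a modest rise. Compound 4 is estimated at 15%, within 3% to 35%.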

Compound 4, a percentage reported as inhibition, at one concentration (the size of the read-out at that concentration, not a potency): 16%
Beside the measured number, compound 4's estimate is 1 percentage points below it; the range from low to high includes it.
By their numbers in this assay, from the lowest: compound 3; then compounds 2 and 4 (each within the scatter of the next); then compound 1.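

In this assay, 2-methoxyphenyl in place of tert-butyl on the aromatic carbon next to the ring nitrogen gives a number 11 percentage points higher from compound 3 to compound 4 (beyond the scatter) in a single-place change, so the number at this position depends on the group it carries. This one pair cannot separate the contribution of the aromatic ring from that of the methoxy oxygen. No available data explain the step.

Still open, going by these compounds, is whether plain phenyl would match 2-methoxyphenyl here. On these data alone, it is also open whether an amine or a carboxylic acid on that ring would shift the number further.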